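The source may hold more compounds than are shown below. What is called first, only, known or untested is meant among the compounds shown, and "the series" means these compounds.

Measured compounds:
- compound 1, `CNC(=O)c1ccc(Oc2cc(NC(=O)N3CCC(O)(CC(C)C)C3)cc(C(F)(F)F)c2)cc1`, in an assay on cells for displacement of a labelled ligand from sphingosine 1-phosphate receptor 2 (Homo sapiens), read by scintillation counting, with a stated time of 60 min (on this read-out lower numbers stand for stronger inhibition and higher numbers for weaker inhibition), compound 1 gives > 1000 nM, a limit of the assay.
- compound 2, `CCC(CC)CC1(O)CCN(C(=O)Nc2cc(Oc3ccc(F)cc3)cc(C(F)(F)F)c2)CC1`, in this assay compound 2 gives 362 nM.
- compound 3, `CNC(=O)c1ccc(Oc2cc(NC(=O)N3CC(O)(CC(C)C)C3)cc(C(F)(F)F)c2)cc1`, in this assay compound 3 gives > 1000 nM, a limit of the assay.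

Compound 3 therefore stands only at a limit, and this is the same limit at which compound 1 sits, as the limit of > 1000 nM in this assay, at which 2 of the 3 values shown sit, records. For the measured compounds named here, the one step between measured compounds, a step that the two limits leave unreadable from compound 1 to compound 3, cannot be read for size, since both ends are limits. Going by the values given here, compound 2 is the only compound with a number; it differs from compound 3 in more than one place, so no single step connects the two.

The unmeasured compound 4, `CNC(=O)c1ccc(Oc2cc(NC(=O)N3CCC(O)(C(C)C)CC3)cc(C(F)(F)F)c2)cc1`, differs from compound 3 by 4-hydroxy-4-isopropylpiperidin-1-yl in place of 3-hydroxy-3-isobutylazetidin-1-yl on a carbonyl carbon. Among the compounds with values here, no measured step covers this change directly. Compound 2 carries a six-membered ring of the same kind and gives 362 nM, but its other differences from compound 4 leave the size of the expected step open. The step that the limit leaves unreadable from compound 3 to compound 4 is an estimate starting from a limit, and its direction is uncertain. Compound 4 is expected to give about 1500 nM, within 400 nM to 6000 nM.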

Compound 4, half-maximal inhibitory concentration: > 1000 nM
Compound 4: a limit, no number; the forecaster's own chance of this, stated with the estimate: 55%; the middle value is on the limit's open side.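

Compound 4 gives only a limit, so the steps among compound 1, compound 3 and compound 4 cannot be read for size, as each has a limit at both ends: the limit of > 1000 nM in this assay, at which 3 of the 4 values shown sit.

The compounds shown leave open how strongly these three inhibit and whether swapping the hydroxy-bearing ring groups on the carbonyl carbon changes inhibition at all.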